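Ureido for chloro on the cyano-pyrimidine core

A few compounds are considered here, and "the series" means these few. Any claim that something is new, unique, unknown or untested is made for them only; others in the source may bear on it.

Measured so far:
compound 1 `N#Cc1c(Cl)nc(SCc2nc3ccccc3[nH]2)nc1-c1ccccc1` — 3.7 nM
compound 2 `N#Cc1c(Nc2ccccc2)nc(SCc2nc3ccccc3[nH]2)nc1-c1ccccc1` — 2.9 nM
compound 3 `N#Cc1c(Nc2nccs2)nc(SCc2nc3ccccc3[nH]2)nc1-c1ccccc1` — 14.7 nM

In a functional assay on KB cells (Homo sapiens) for cytotoxicity, read by MTT assay, with a stated time of 3 days (a higher number here means a weaker inhibitor, a lower number a stronger inhibitor), compound 1 gives 3.7 nM. Of the three numbers, compound 1 stands with compound 2 inside the scatter, the pair separated by a 1.3-fold lower number from compound 1 to compound 2 (0.11 log units; within the scatter), and only compound 3 lies apart from it, higher, by a 4.0-fold higher number from compound 1 to compound 3 (0.60 log units; beyond the scatter). Compound 3 also sits above compound 2 by a 5.1-fold higher number from compound 2 to compound 3 (0.70 log units; beyond the scatter).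

Compound 4 `N#Cc1c(NC(N)=O)nc(SCc2nc3ccccc3[nH]2)nc1-c1ccccc1` is not yet measured. It differs from compound 1 as follows: ureido in place of chloro on an aromatic carbon

Within the data shown here, two measured steps bear on this: replacing chloro by anilino left the number unchanged within scatter, while replacing chloro by (1,3-thiazol-2-yl)amino raised it modestly. Among the measured compounds shown here, a ureido group has no direct precedent here, so the expectation in this assay is a small weakening at most, of the order of the larger of those two steps or less, i.e. a 2.7-fold higher number from compound 1 to compound 4 (0.43 log units; beyond the scatter). Compound 4 is thus estimated at 10 nM, with a range of 3 nM to 40 nM.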

Compound 4, half-maximal inhibitory concentration: 9.6 nM
Compound 4: the middle estimate sits 1.0-fold (0.02 log units) above what was measured; low and high end bracket the measured number.
By their numbers in this assay, from the lowest: compounds 2 and 1 (each within the scatter of the next); then compounds 4 and 3 (each within the scatter of the next).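

In this assay, a substituent with no ring can stand at this position, but ureido in place of chloro gives a 2.6-fold higher number from compound 1 to compound 4 (0.41 log units; beyond the scatter). With the attached nitrogen kept, carbamoyl in place of 1,3-thiazol-2-yl gives a 1.5-fold lower number from compound 3 to compound 4 (0.19 log units; within the scatter), so a ring on that nitrogen is not needed for a number in this range, while carbamoyl in place of phenyl gives a 3.3-fold higher number from compound 2 to compound 4 (0.52 log units; beyond the scatter), leaving anilino the only one of the three nitrogen-linked groups with a step beyond the scatter to both others. No measurement available here explains these differences.

Going by these compounds, whether a plain amine or an acetamido group at this position would fall with compound 1 or with compound 4 remains open. On these data alone, the effect of a longer chain on the ureido also remains open.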